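Swapping Fluoro for Methoxy: Expected Solubility

A few compounds are considered here, and "the series" means these few. Any claim that something is new, unique, unknown or untested is made for them only; others in the source may bear on it.

Measured compounds:
compound 1, `Cc1cc(NCc2ccccn2)n2nc(C)c(-c3ccc(F)cc3)c2n1`: < 5000 nM
compound 2, `Cc1cc(NCc2ccccn2)n2ncc(-c3ccc(F)cc3)c2n1`: < 5000 nM

Of the compounds shown here, two have been measured in a physicochemical assay for solubility, read by HPLC, using the shake flask method, measured as kinetic solubility, with a stated time of 2 h, at pH 7.4; a lower number here means a less soluble compound, a higher number a more soluble compound. For compound 1 the reported value is a limit of the assay, < 5000 nM. For compound 2 the reported value is likewise a limit, < 5000 nM. For the measured compounds named here, compound 1 therefore has no exact number in this assay, only a limit, and the one further value shown is also a limit. Going by the values given here, the single comparison between measured compounds, hydrogen in place of methyl on an aromatic carbon, is a step that the two limits leave unreadable from compound 1 to compound 2. Both values sit at the limit of < 5000 nM in this assay, at which 2 of the 2 values shown sit.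

The compound still to be measured is compound 3, `COc1ccc(-c2c(C)nn3c(NCc4ccccn4)cc(C)nc23)cc1`. It differs from compound 1 by methoxy in place of fluoro on an aromatic carbon. Among the compounds with values here, no measured step touches this change, and the two measured values give no size to any step at all. The expected step is a step that the limit leaves unreadable from compound 1 to compound 3, which amounts to no readable change. Compound 3 is estimated at 3000 nM in this assay, within a range from 500 nM to 15000 nM, and it is expected most likely to be reported only as a limit as well.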

Compound 3, solubility: < 5000 nM
Compound 3: only a limit was reported (the forecaster's own chance of this, stated with the estimate: 70%); the middle value is on the limit's open side.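

For the compounds shown here, compound 3, like compound 1, is reported only as a limit of the assay and not as a number, so no step between them can be read. In this assay, the three compounds share one reported result: the limit of < 5000 nM in this assay, at which 3 of the 3 values shown sit. Going by these compounds, the actual solubility of each compound, and whether swapping fluoro for methoxy changes it, stays open.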